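Working notes: from compound 2 toward compound 3

The source may hold more compounds than are shown below. What is called first, only, known or untested is meant among the compounds shown, and "the series" means these compounds.

Two members of the set have so far been run in an ADME assay on HEK293 cells (Homo sapiens) for inhibition, with a stated time of 72 h; on this read-out lower numbers stand for an effect already at smaller amounts and higher numbers for an effect only at larger amounts of compound. Compound 1 `O=C(Nc1ccc(Cl)cc1)c1cc([N+](=O)[O-])ccc1Cl` gives > 25000 nM, which is a limit of the assay and not a number. Compound 2 `O=C(O)/C=C/C(=O)Nc1cccc(-c2nc3ccccc3s2)c1` gives > 25000 nM, again a limit rather than a measured number. Among the measured compounds shown here, compound 2 therefore stands where every value so far sits, namely at the limit of > 25000 nM in this assay, at which 2 of the 2 values shown sit. For the measured compounds named here, no step between measured compounds is available, and the two values only show that neither compound reaches the measurable range of this assay.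

Compound 3 `CC(Cl)C(=O)Nc1cccc(-c2nc3ccccc3s2)c1` is not yet measured. It differs from compound 2 by 1-chloroethyl in place of 2-carboxyethenyl on a carbonyl carbon, in words 1-chloroethyl in place of 2-carboxyethenyl on a carbonyl carbon. Going by the values given here, with no measured step to compare against and both known values sitting at the limit, the expectation for compound 3 is a step of a number no higher from compound 2 to compound 3 (the limit leaves the size open) of no clear direction, not reliably beyond the scatter. Compound 3 is expected at 25000 nM, with a range from 8000 nM to 60000 nM.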

Compound 3, half-maximal effective concentration: > 25000 nM
Compound 3 ended at the assay's limit; the forecaster's own chance of this, stated with the estimate: 60%; the middle value sits exactly at the limit.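

No step from compound 2 to compound 3 can be read, since the values for both compounds are limits of the assay and not numbers: the limit of > 25000 nM in this assay, at which 3 of the 3 values shown sit.

The compounds shown leave open how far each one lies past that limit, and which structural change, if any, would give a measured number.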